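Aryl variation at the core: compound 3 to compound 4

The source may report more compounds than this note shows. Statements on the series, on what has been measured and on what is new or still open speak of the compounds shown alone.

Three compounds of the series carry the same fused core and differ in the aryl group on it and in the substituent on the other ring. In a functional assay on U-251 cells (Homo sapiens) for inhibition, read by sulforhodamine B assay, with a stated time of 48 h, tested at 10 uM (a lower number here means less inhibition, a higher number more inhibition at the concentration tested (going by the name of the read-out)), compound 1 `COc1ccc(-c2cn3ccnc3c(-c3ccc4ncn(C5CCCCC5)c4c3)n2)cc1` gives 80.9%, and compound 2 `c1csc(-c2cn3ccnc3c(-c3ccc4ncn(C5CCCCC5)c4c3)n2)c1` gives 3.92%. Compound 3 `CCc1ccc(-c2cn3ccnc3c(-c3ccc4ncn(Cc5ccccc5)c4c3)n2)cc1` gives 46.1% in this assay, second highest of the three numbers: it lies beyond the scatter below compound 1 and beyond the scatter above compound 2.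

The unmeasured compound 4 `Cc1cccc(-c2cn3ccnc3c(-c3ccc4ncn(Cc5ccccc5)c4c3)n2)c1` differs from compound 3 in one place: 3-methylphenyl in place of 4-ethylphenyl on an aromatic carbon.

For the measured compounds named here, the only measured step at this position is a number 77 percentage points lower from compound 1 to compound 2 (beyond the scatter), a swap of a substituted phenyl for a five-membered heteroaryl. That step bears on compound 4 only loosely, as the change from compound 3 to compound 4 keeps a phenyl ring and alters just its small carbon substituent. Going by the values given here, no measured pair shows a methyl for ethyl or a shift of the substituent around the phenyl ring. The expected step is therefore small, a number 8.1 percentage points lower from compound 3 to compound 4 (within the scatter), possibly within the scatter, with a slight lean downward given that compound 1 with its para-substituted phenyl gives 80.9%. Compound 4 is estimated at 38%, within a range of 10% to 65%.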

Compound 4, a percentage reported as inhibition, at one concentration (the size of the read-out at that concentration, not a potency): 19.4%
Estimate against measurement, compound 4: 18.6 percentage points above; low and high end bracket the measured number.
By their numbers in this assay, from the lowest: compound 2; then compound 4; then compound 3; then compound 1.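

In this assay the replacement of 4-ethylphenyl by 3-methylphenyl gives a number 26.7 percentage points lower from compound 3 to compound 4 (beyond the scatter), so this position responds to a change that keeps the six-membered aromatic ring of carbon, whereas the earlier step, a number 77 percentage points lower from compound 1 to compound 2 (beyond the scatter), showed only the response to a swap of the phenyl ring for thiophen-2-yl. The series is therefore sensitive here to small carbon substituents on the phenyl ring, although the leaving group has 8 heavy atoms and the entering group 7, and neither has a hydrogen-bond donor or acceptor. The evidence at hand gives no explanation for the size of this step.

Because the chain length and the place on the phenyl ring change together, the compounds shown leave open how much of the step belongs to each, a question that 4-methylphenyl or 3-ethylphenyl on the same core would separate. Also open, from the compounds shown here alone, are a primary amine or a carboxylic acid on this phenyl ring, and whether the step carries over to the core of compound 1 with its cyclohexyl group.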